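The compounds below may be only part of what the source reports. "The series", "measured", "known", "first", "only" and "open" are said of these compounds alone.

Measured compounds:
Compound 1 `Cn1c(COc2cccc(C(=O)O)c2)nc2ccc(Oc3cccc(Cl)n3)cc21` gives 7.6 10^-6 cm/s in an ADME assay for permeability, using PAMPA, with a stated time of 4 h; on this read-out lower numbers stand for lower permeability and higher numbers for higher permeability.
Compound 2 `Cn1c(COc2cccc(C(=O)O)c2)nc2ccc(Oc3ncccc3Cl)cc21` gives 8.1 10^-6 cm/s in this assay.
Compound 3 `Cc1cccc(Oc2ccc3nc(COc4cccc(C(=O)O)c4)n(C)c3c2)n1` gives 2.7 10^-6 cm/s in this assay.

Compound 3 stands lowest of the three: the steps of a 2.8-fold lower number from compound 1 to compound 3 (0.45 log units; beyond the scatter) and a 3.0-fold lower number from compound 2 to compound 3 (0.48 log units; beyond the scatter) both lie beyond the scatter, whereas the step of a 1.1-fold higher number from compound 1 to compound 2 (0.03 log units; within the scatter) lies within it. Compound 4 `Cn1c(COc2cccc(C(=O)O)c2)nc2ccc(Oc3ccc(F)cn3)cc21` differs from compound 3 in one place: 5-fluoropyridin-2-yl in place of 6-methylpyridin-2-yl on an oxygen on an aromatic ring. The two steps that lead to compound 3 bear on this change, as each swaps a chloro-bearing pyridinyl for the methyl-bearing one, and compound 4 again carries a halogen on the pyridinyl. A modest rise is therefore expected, roughly undoing those steps: a 2.2-fold higher number from compound 3 to compound 4 (0.35 log units; beyond the scatter). Compound 4 is thus expected to give about 6 10^-6 cm/s, most likely between 3 10^-6 cm/s and 12 10^-6 cm/s.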

Compound 4, apparent permeability: 4.7 10^-6 cm/s
Beside the measured number, compound 4's estimate is 1.3-fold (0.11 log units) above it; the measured number falls inside the stated range.
By their numbers in this assay, from the lowest: compounds 3, 4, 1 and 2 (each within the scatter of the next, the first and the last beyond it).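

In this assay, 5-fluoropyridin-2-yl on this oxygen cannot be told apart from any of the three earlier groups: a 1.7-fold higher number from compound 3 to compound 4 (0.24 log units; within the scatter) and a 1.7-fold lower number from compound 2 to compound 4 (0.24 log units; within the scatter) and a 1.6-fold lower number from compound 1 to compound 4 (0.21 log units; within the scatter) all lie within the scatter. The earlier split between the chloro-bearing groups and 6-methylpyridin-2-yl therefore places this fluoro-bearing group on neither side. Nothing measured here explains these numbers. Still open, from the compounds shown here alone, is whether fluoro and chloro would differ on the same ring position, as 5-chloropyridin-2-yl would show, and how a pyridinyl group carrying an amine would read in this assay.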